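Prop-1-yn-1-yl Gives Way to Methylsulfanyl on a Shared Core

The source may report more compounds than this note shows. Statements on the series, on what has been measured and on what is new or still open speak of the compounds shown alone.

Of the compounds shown here, three built on one core have been measured. Going by the values given here, compound 1 `CC1CCCC(Oc2cccc3ccc(N)nc23)C1` is the only one with a number: in an assay on cells with melanin-concentrating hormone receptor 1 (Homo sapiens) as the target, read by radioligand binding (on this read-out lower numbers stand for stronger inhibition and higher numbers for weaker inhibition), compound 1 gives 640 nM. Compound 3 `CC(CC(C)(C)C)Oc1cccc2ccc(N(C)C)nc12` returns only a limit of the assay, and in this assay compound 3 gives > 2000 nM. Compound 2 `CC#CCCOc1cccc2ccc(N)nc12` likewise returns only a limit, not a number, and in this assay compound 2 gives > 2000 nM. Compound 2 therefore stands at the limit of > 2000 nM in this assay, at which 2 of the 3 values shown sit, so its true affinity is known only to be weaker than that limit.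

Compound 4 `CSCCOc1cccc2ccc(N)nc12` has not yet been measured. It differs from compound 2 in one place: methylsulfanyl in place of prop-1-yn-1-yl on a saturated chain carbon, two bonds along the chain from an oxygen on an aromatic ring. Among the compounds with values here, no pair of measured compounds differs in a single place, so no measured step sets the scale for this change. Compound 2 in this assay gives only a limit, > 2000 nM. The expected step that the limit leaves unreadable from compound 2 to compound 4 is none beyond the scatter. Compound 4 is expected in this assay to give about 2500 nM, within a range from 800 nM to 8000 nM. There is a substantial chance that compound 4 again yields only a limit rather than a number.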

Compound 4, half-maximal inhibitory concentration: > 2000 nM
Compound 4: only a limit was reported; the forecaster's own chance of this, stated with the estimate: 60%; the middle value does not contradict the limit.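

In this assay compound 4, like compound 2, returns only a limit, so no step can be read between the two: the limit of > 2000 nM in this assay, at which 3 of the 4 values shown sit. The compounds shown leave open whether methylsulfanyl in place of prop-1-yn-1-yl changes the affinity at all and, if it does, in which direction and by how much.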